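A fluoro on the anilino ring of compound 2

The source may report more compounds than this note shows. Statements on the series, on what has been measured and on what is new or still open speak of the compounds shown alone.

Compound 1 `NC(=O)c1c(NC(=O)c2ccccc2Cl)sc2c1CCNC2`: in a functional assay on HL-60 cells (Homo sapiens) for antiproliferative activity, with a stated time of 24 h (a lower number here means a stronger inhibitor, a higher number a weaker inhibitor), compound 1 gives 18600 nM.
Compound 2 `NC(=O)c1c(NC(=O)c2ccccc2Cl)sc2c1CCN(C(=S)Nc1ccccc1)C2`: in this assay compound 2 gives 5940 nM.

Going by the values given here, of the two measured compounds, compound 2 has the lowest number; its only neighbour is compound 1, and the step of a 3.1-fold lower number from compound 1 to compound 2 (0.50 log units; beyond the scatter) lies beyond the scatter. Compound 3 `NC(=O)c1c(NC(=O)c2ccccc2Cl)sc2c1CCN(C(=S)Nc1ccccc1F)C2` differs from compound 2 by fluoro in place of hydrogen on an aromatic carbon. Among the compounds with values here, the one measured step concerns the whole thiourea group that enters on the amine nitrogen in the ring and brings the phenyl ring with it; it says nothing about a substituent on that phenyl ring. Within the data shown here, no measured pair shows a fluoro in place of hydrogen on an aromatic carbon, so the data give no direction for this change. In this assay compound 3 is therefore expected to stay close to compound 2, with a step not beyond the scatter. The estimated step of a 1.2-fold lower number from compound 2 to compound 3 (0.07 log units; within the scatter) is expected to be small. Compound 3 is estimated at 5000 nM, with a range from 2000 nM to 15000 nM.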

Compound 3, half-maximal inhibitory concentration: 4970 nM
Compound 3: middle estimate off by 1.0-fold (0.00 log units), on the high side; the measured number falls inside the stated range.
By their numbers in this assay, from the lowest: compounds 3 and 2 (each within the scatter of the next); then compound 1.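

In this assay, the only change shown on the phenyl ring itself, phenyl to 2-fluorophenyl, gives a 1.2-fold lower number from compound 2 to compound 3 (0.08 log units; within the scatter), so a fluoro on this aromatic carbon ortho to a large group leaves the number within the scatter and compounds 2 and 3 cannot be told apart. Set against the free amine nitrogen in the ring of compound 1, the whole group carrying the fluoro gives a 3.7-fold lower number from compound 1 to compound 3 (0.57 log units; beyond the scatter), so the modest difference first seen with the plain phenyl ring also holds with the 2-fluorophenyl ring in its place. No measured evidence is available to explain either step.

Since a single fluoro is the only substituent shown on this ring, it remains open whether a chloro, a methyl, a methoxy or a trifluoromethyl group on the same carbon would also leave the number within the scatter, or whether a fluoro on another carbon of the ring would do so. From the compounds shown here alone, it also remains open how far the number would move if an amine or a carboxylic acid were placed on this ring, or if the phenyl ring gave way to a longer alkyl chain.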